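The compounds below may be only part of what the source reports. "The series", "measured", "known", "first", "only" and "open" are said of these compounds alone.

Among the measured compounds shown here, compound 2 `CCCCCCCCCCCCOC(=O)CCC(=O)N1CCN(CCCOc2cc3c(Nc4ccc(F)c(Cl)c4)ncnc3cc2OC)CC1` in a functional assay on A549 cells (Homo sapiens) for cytotoxicity, read by MTT assay, with a stated time of 24 h, tested at 40 uM (on this read-out higher numbers stand for a weaker effect at the one concentration tested and lower numbers for a stronger effect), gives 5.7%, the lowest of the two numbers known. Compound 1 `CCCCCOC(=O)CCC(=O)N1CCN(CCCOc2cc3c(Nc4ccc(F)c(Cl)c4)ncnc3cc2OC)CC1` gives 63.6% in this assay, and the step of a number 57.9 percentage points lower from compound 1 to compound 2 (beyond the scatter) went with heptyl in place of hydrogen on a saturated chain carbon, five bonds along the chain from an oxygen next to a carbonyl group. Compound 3 `CCCCCCCCCCCCCCCCCCCCOC(=O)CCC(=O)N1CCN(CCCOc2cc3c(Nc4ccc(F)c(Cl)c4)ncnc3cc2OC)CC1` carries the change (octyl in place of hydrogen on a saturated chain carbon, ten or more bonds along the chain from an oxygen next to a carbonyl group). That earlier lengthening was large and downward, but compound 2 already sits close to the bottom of the read-out, so the expected step of a number 0.7 percentage points lower from compound 2 to compound 3 (within the scatter) is none beyond the scatter. Compound 3 is estimated at 5%, between 0% and 16%.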

Compound 3, a percentage reported as activity, at one concentration (the size of the read-out at that concentration, not a potency): 87.1%
For compound 3 the middle estimate is 82.1 percentage points below the measured one; the measured number lies above the stated range.
By their numbers in this assay, from the lowest: compound 2; then compound 1; then compound 3.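

In this assay, lengthening this chain does not push the read-out one way: octyl at this place gives a number 81.4 percentage points higher from compound 2 to compound 3 (beyond the scatter), a large step that runs opposite to the earlier a number 57.9 percentage points lower from compound 1 to compound 2 (beyond the scatter). Of the three compounds, compound 2 therefore shows the strongest effect, and its chain length is the only one shown with a low number. Nothing measured here explains this reversal. The compounds shown leave open where the effect is lost between these two chain lengths, which a hexadecyl chain could help to locate. They also leave open whether a chain ending in a carboxylic acid would behave alike.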